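This account rests on a few compounds, and the source may have more. Where it says the series, first, only, none or still open, it means among the compounds named here.

Three compounds share a core in which two aromatic rings are joined through a sulfur atom. Compound 1 `N#Cc1ccc(Sc2ccc(Br)cc2)cc1C#N` carries two nitrile groups and a bromo group; in an assay on microsomes for inhibition of Amine oxidase [flavin-containing] A (Homo sapiens), read by fluorescence and spectrophotometry, with a stated time of 20 min (a higher number here means a weaker inhibitor, a lower number a stronger inhibitor), compound 1 gives 19000 nM. Compound 2 `N#Cc1ccc(Sc2ccccc2)cc1` has one nitrile and an unsubstituted second ring, and compound 2 gives 36900 nM. Compound 3 `N#Cc1ccc(Sc2ccc(Cl)cc2)cc1` adds a chloro group to that ring, and compound 3 gives 18200 nM, at the low end of the numbers shown, with compound 1 within the scatter of it and compound 2 beyond. Among the measured compounds shown here, the single one-change step measured is a 2.0-fold lower number from compound 2 to compound 3 (0.31 log units; beyond the scatter). Compound 4 `N#Cc1ccc(Sc2ccc(Br)cc2)cc1` differs from compound 3 by bromo in place of chloro on an aromatic carbon. For the measured compounds named here, no measured step swaps one halogen for another; compound 1, bromo-bearing, sits close to compound 3. The expected step is therefore small, a 1.2-fold lower number from compound 3 to compound 4 (0.08 log units; within the scatter). For compound 4 the estimate is 15000 nM, between 7000 nM and 35000 nM.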

Compound 4, half-maximal inhibitory concentration: 8520 nM
Compound 4: the middle estimate sits 1.8-fold (0.25 log units) above what was measured; the range from low to high includes it.
By their numbers in this assay, from the lowest: compound 4; then compounds 3, 1 and 2 (each within the scatter of the next, the first and the last beyond it).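

Bromo in place of chloro gives a 2.1-fold lower number from compound 3 to compound 4 (0.33 log units; beyond the scatter) in this assay at this position, so the two halogens can be told apart here, which no earlier step could show. Bromo in place of hydrogen on the same carbon gives a 4.3-fold lower number from compound 2 to compound 4 (0.64 log units; beyond the scatter) in this measure. Hydrogen in place of cyano gives a 2.2-fold lower number from compound 1 to compound 4 (0.35 log units; beyond the scatter) with bromo kept, so the second nitrile brings no lower number here.

As far as these compounds go, whether iodo, methoxy or an amine on that carbon would go lower stays open. Nothing on hand explains the difference between bromo and chloro.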